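The source may hold more compounds than are shown below. What is called first, only, known or untested is meant among the compounds shown, and "the series" means these compounds.

Compound 1 `O=C(Nc1nccn2cc(-c3ccccc3)nc12)c1ccccc1` is the reference point of this small set. In an assay on cells for displacement of a labelled ligand from adenosine receptor A1 (Homo sapiens), read by scintillation counting, with a stated time of 120 min, tested at 1 uM (a lower number here means less inhibition, a higher number more inhibition at the concentration tested (going by the name of the read-out)), compound 1 gives 18%, the lowest of the three numbers recorded, though its distance to each of the other two is within the scatter. Compound 2 `Cc1ccc(C(=O)Nc2nccn3cc(-c4ccccc4)nc23)cc1` gives 26% in this assay, and compound 3 `O=C(Nc1nccn2cc(-c3ccccc3)nc12)c1ccco1` gives 25%. The three steps between them, a number 8 percentage points higher from compound 1 to compound 2 (within the scatter), a number 7 percentage points higher from compound 1 to compound 3 (within the scatter) and a number 1 percentage points lower from compound 2 to compound 3 (within the scatter), all stay within the scatter, so the three numbers are level with one another and none of the three compounds can be said to give a higher or lower number than another.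

Compound 4 `O=C(Nc1nccn2cc(-c3ccco3)nc12)c1ccccc1` has not yet been measured. It differs from compound 1 by furan-2-yl in place of phenyl on an aromatic carbon. For the measured compounds named here, the one measured step that bears on this change is the exchange of phenyl for furan-2-yl on the carbonyl carbon, a number 7 percentage points higher from compound 1 to compound 3 (within the scatter), which lay within the scatter. Going by the values given here, the step to compound 4 moves the same exchange to the core instead, and no measured pair shows that exchange at that place. On the evidence of compound 3 alone, the account expects no step beyond the scatter, a number 2 percentage points higher from compound 1 to compound 4 (within the scatter). Compound 4 is therefore estimated to give 20% in this assay, with a range from 8% to 34%.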

Compound 4, a percentage reported as inhibition, at one concentration (the size of the read-out at that concentration, not a potency): 7%
For compound 4 the middle estimate is 13 percentage points above the measured one, and the stated range ends above it.
By their numbers in this assay, from the lowest: compound 4; then compounds 1, 3 and 2 (each within the scatter of the next).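

For the compounds shown here, on the aromatic carbon of the five-membered aromatic ring with 2 nitrogen, the exchange of phenyl for furan-2-yl gives the first step in this set that leaves the scatter: in this assay it is a number 11 percentage points lower from compound 1 to compound 4 (beyond the scatter). The same exchange on the carbonyl carbon, a number 7 percentage points higher from compound 1 to compound 3 (within the scatter), stayed within the scatter, so among these compounds the step seen for this exchange differs with the place where it is made, and the result at the carbonyl carbon could not stand in for the result on the core. Nothing measured here accounts for this difference between the two places.

The compounds shown carry only phenyl and furan-2-yl at this place on the core, so they leave open whether the lower number belongs to furan-2-yl in particular or would also appear with another group there, such as thiophen-2-yl, cyclohexyl or an amine. They also leave open whether the step on the core would be the same with 4-methylphenyl or furan-2-yl in place of phenyl on the carbonyl carbon.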